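Removing trifluoromethyl from the carbocyclic aromatic ring

The source may hold more compounds than are shown below. What is called first, only, known or untested is meant among the compounds shown, and "the series" means these compounds.

compound 1 `O=c1oc2cccnc2n1CN1CCN(c2cccc(C(F)(F)F)c2)CC1`: 25%
compound 2 `O=c1oc2cccnc2n1CCN1CCN(c2ccc(F)cc2)CC1`: 16%

Of the compounds shown here, two that share a common core have been tested in a functional assay on the whole organism for inhibition, with Rattus norvegicus as the target, read by paw edema, at a dose of 50 mg/kg; a higher number here means more inhibition at the dose given (going by the name of the read-out), a lower number less inhibition. Compound 1 gives 25% in this assay. Compound 2, which carries a different chain between the core and the ring-bearing portion and a different aromatic substituent, gives 16% in this assay. The two numbers lie within the usual scatter of each other, so the data establish no order between compound 1 and compound 2; compound 1 can only be said to sit alongside compound 2.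

Compound 3 `O=c1oc2cccnc2n1CN1CCN(c2ccccc2)CC1` has not yet been measured. It differs from compound 1 in one place: hydrogen in place of trifluoromethyl on an aromatic carbon. Among the compounds with values here, no step between measured compounds corresponds to this change, so the expectation rests on the scatter of this assay alone. The change is expected to give a step in this assay of the size a number 5 percentage points lower from compound 1 to compound 3 (within the scatter), which is not expected to exceed the scatter, with a slight downward lean because compound 1 itself gives 25% and nothing here points to a gain. Compound 3 is therefore estimated at 20%, in a range from 5% to 35%.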

Compound 3, a percentage reported as inhibition, in the whole organism at one dose (the size of the read-out at that dose, not a potency): 11%
Beside the measured number, compound 3's estimate is 9 percentage points above it; the measured number falls inside the stated range.
By their numbers in this assay, from the lowest: compounds 3, 2 and 1 (each within the scatter of the next, the first and the last beyond it).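

Within the data shown here, compound 1 and compound 3 form the first pair here that differs in one place only, so the effect of a single change can now be read in this assay. Replacing trifluoromethyl with hydrogen on an aromatic carbon, meta to a large group, gives a number 14 percentage points lower from compound 1 to compound 3 (beyond the scatter), a loss that clears the scatter even though it removes only 4 heavy atoms and no ring. At this position, then, the inhibition seen at the given dose depends in part on which group the ring carries, although this rests on a single pair and no measurement here explains the step.

The compounds shown leave open whether the inhibition follows trifluoromethyl in particular or would also appear with another group in the same place, such as chlorine, methoxy or a nitrile. They also leave open whether the same replacement would give a step of similar size on a compound with a longer chain between the shared core and the ring-bearing portion.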